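The compounds below may be only part of what the source reports. "The series", "measured", "known", "first", "only" and "open" are said of these compounds alone.

Measured in an assay on RBL-1 cells for inhibition of Polyunsaturated fatty acid 5-lipoxygenase (Rattus norvegicus); a lower number here means a stronger inhibitor, a higher number a weaker inhibitor:

compound 1 `Cc1ccccc1N1CCNC(=O)N1`: 386000 nM
compound 2 `O=C1NCCN(c2cccc(F)c2)N1`: 19000 nM
compound 3 `Cc1cccc(N2CC(C)NC(=O)N2)c1`: 19000 nM

Compound 3 stands level with compound 2 at the digits shown, and together these two are the lowest of the three numbers; the difference between them lies within the scatter. Within the data shown here, the only clearly separated member is compound 1, whose number sits far above that of compound 3, well beyond the scatter. Among the measured compounds shown here, no single-change step between measured compounds is available, so no measured step can be quoted.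

Compound 4 `CC1CN(c2cccc(F)c2)NC(=O)N1` is the next member to be measured in this assay. Relative to compound 3 the change is fluoro in place of methyl on an aromatic carbon. Compound 2 already carries fluoro on its aromatic ring and compound 3 carries methyl there, and their values coincide at the digits shown, though they also differ in the core. On that basis the step of no change at the digits printed from compound 3 to compound 4 (within the scatter) is expected to be none beyond the scatter. Compound 4 is therefore estimated at 19000 nM, with a range from 8000 nM to 45000 nM.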

Compound 4, half-maximal inhibitory concentration: 6300 nM
For compound 4 the middle estimate is 3.0-fold (0.48 log units) above the measured one, and the stated range ends above it.
By their numbers in this assay, from the lowest: compound 4; then compounds 2 and 3 (each within the scatter of the next); then compound 1.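

In this assay the aromatic carbon meta to a group of 8 heavy atoms now shows a single change that can be read: fluoro in place of methyl gives a 3.0-fold lower number from compound 3 to compound 4 (0.48 log units; beyond the scatter), which compound 2 and compound 3, differing in two places, could not isolate. On a saturated ring carbon, methyl in place of hydrogen gives a 3.0-fold lower number from compound 2 to compound 4 (0.48 log units; beyond the scatter), so the level values of compound 2 and compound 3 conceal two separate steps, each leading to compound 4. No measurement bearing on the origin of either step is available.

Going by these compounds, whether the fluoro step extends to chloro, methoxy or trifluoromethyl on that aromatic carbon stays open. Also open, on these data alone, is whether ethyl or hydroxymethyl on the saturated ring carbon would follow the methyl step.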